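Nitrogen substituent exchange and tolerance on Vero cells

A few compounds are considered here, and "the series" means these few. Any claim that something is new, unique, unknown or untested is made for them only; others in the source may bear on it.

Compound 1 `CC(=O)OC[C@H]1O[C@@H](CC(=O)/C=C2\C(=O)N(Cc3ccc(Br)cc3)c3ccccc32)[C@H](OC(C)=O)[C@@H](OC(C)=O)[C@@H]1OC(C)=O`: 76500 nM
Compound 2 `CCCN1C(=O)/C(=C\C(=O)C[C@@H]2O[C@H](COC(C)=O)[C@@H](OC(C)=O)[C@H](OC(C)=O)[C@H]2OC(C)=O)c2cc(Cl)ccc21`: 95600 nM
Compound 3 `CCCCN1C(=O)/C(=C\C(=O)C[C@@H]2O[C@H](COC(C)=O)[C@@H](OC(C)=O)[C@H](OC(C)=O)[C@H]2OC(C)=O)c2cc(Cl)ccc21`: 88900 nM

In an ADME assay on Vero cells (Chlorocebus sabaeus) for cytotoxicity, read by resazurin assay, with a stated time of 72 h (a lower number here means that less compound is tolerated, a higher number that more compound is tolerated), compound 3 gives 88900 nM, the second highest of the three numbers, with compound 2 nearest and compound 1 furthest, both within the scatter. Compound 4 `CC(=O)OC[C@H]1O[C@@H](CC(=O)/C=C2\C(=O)N(Cc3ccc(Br)cc3)c3ccc(Cl)cc32)[C@H](OC(C)=O)[C@@H](OC(C)=O)[C@@H]1OC(C)=O` differs from compound 3 by 4-bromophenyl in place of propyl on a saturated chain carbon bound to an amide-type nitrogen in a ring. Among the measured compounds shown here, only one measured step touches this position: a 1.1-fold lower number from compound 2 to compound 3 (0.03 log units; within the scatter), a chain lengthening with no effect beyond the scatter. Compound 1 and compound 3 show the same picture, since compound 1 already carries the 4-bromobenzyl group and gives 76500 nM, close to compound 3. No step beyond the scatter is therefore expected in this assay. Compound 4 is estimated at 80000 nM, between 40000 nM and 160000 nM. The expected step is a 1.1-fold lower number from compound 3 to compound 4 (0.05 log units; within the scatter).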

Compound 4, half-maximal cytotoxic concentration: 93300 nM
Compound 4: middle estimate off by 1.2-fold (0.07 log units), on the low side, within the range that was stated.
By their numbers in this assay, from the lowest: compounds 1, 3, 4 and 2 (each within the scatter of the next).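

In this assay, with the chloro group in place, 4-bromobenzyl on the ring nitrogen is tolerated like the plain chains, with a 1.0-fold higher number from compound 3 to compound 4 (0.02 log units; within the scatter) and a 1.0-fold lower number from compound 2 to compound 4 (0.01 log units; within the scatter) on the same reading. The chloro group on an aromatic carbon, now read with the 4-bromobenzyl group held constant, also stays within the scatter, with a 1.2-fold higher number from compound 1 to compound 4 (0.09 log units; within the scatter) in this pair. Neither exchange therefore carries a number beyond the scatter.

On these data alone, whether an amine or a carboxylic acid in place of the 4-bromobenzyl group would stay within the scatter remains open. Why these numbers lie so close also remains open, as no supporting data bear on it.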